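This account rests on a few compounds, and the source may have more. Where it says the series, first, only, none or still open, it means among the compounds named here.

Measured in a functional assay on MCF7 cells (Homo sapiens) for antiproliferative activity, read by CellTiter-Glo, with a stated time of 5 days; on this read-out higher numbers stand for weaker inhibition and lower numbers for stronger inhibition:
- Compound 1 `CC1=C(c2ccc(S(C)(=O)=O)cc2)C(c2ccc(OC[C@H](C)N3CC[C@@H](C)C3)cc2)Oc2ccc(O)cc21`: 27 nM
- Compound 2 `CC1=C(c2ccccc2)C(c2ccc(OC[C@H](C)N3CC[C@@H](C)C3)cc2)Oc2ccc(O)cc21`: 0.4 nM
- Compound 3 `CC1=C(c2cccc(F)c2)C(c2ccc(OC[C@H](C)N3CC[C@@H](C)C3)cc2)Oc2ccc(O)cc21`: 1 nM

Compound 3 holds the middle place among these three numbers. Compound 4 `CC1=C(c2ccc(O)cc2)C(c2ccc(OC[C@H](C)N3CC[C@@H](C)C3)cc2)Oc2ccc(O)cc21` carries 4-hydroxyphenyl in place of 3-fluorophenyl on a double-bonded ring carbon.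

Going by the values given here, three measured steps bear on this change. Adding fluoro gave a modest step, a 2.5-fold higher number from compound 2 to compound 3 (0.40 log units; beyond the scatter). Among the compounds with values here, the 4-(methylsulfonyl)phenyl of compound 1 is the only other substituted group at this place, and it stands out in two large steps: a 68-fold lower number from compound 1 to compound 2 (1.83 log units; beyond the scatter) and a 27-fold lower number from compound 1 to compound 3 (1.43 log units; beyond the scatter). Within the data shown here, no measured compound carries a hydroxy group here, so this comparison is only a loose guide.

A small move is expected, not a large loss like that seen with compound 1: a 1.7-fold lower number from compound 3 to compound 4 (0.22 log units; within the scatter). The estimate for compound 4 is 0.6 nM, with an expected range of 0.2 nM to 2 nM.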

Compound 4, half-maximal inhibitory concentration: 0.1 nM
The estimate for compound 4 lay 6.0-fold (0.78 log units) above the measured number; measured number below the stated range.
By their numbers in this assay, from the lowest: compound 4; then compound 2; then compound 3; then compound 1.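

In this assay, a substituent on this phenyl ring need not weaken inhibition: a hydroxy group strengthens it over both hydrogen (a 4.0-fold lower number from compound 2 to compound 4 (0.60 log units; beyond the scatter)) and the 3-fluorophenyl group (a 10-fold lower number from compound 3 to compound 4 (1.00 log units; beyond the scatter)). Fluoro and methylsulfonyl, the earlier substituents, both went the other way, and the contrast with methylsulfonyl is now the widest in the set (a 270-fold lower number from compound 1 to compound 4 (2.43 log units; beyond the scatter)). No measurement here explains why the hydroxy group behaves differently.

Going by these compounds, whether a methoxy group or an amine in place of the hydroxy would keep this strength remains open. So does whether the hydroxy group needs its particular place on the ring.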